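Trimming the terminal amide of compound 1

This account rests on a few compounds, and the source may have more. Where it says the series, first, only, none or still open, it means among the compounds named here.

Two members of the series have numbers in an assay on HEK293 cells for displacement of a labelled ligand from NPC1-like intracellular cholesterol transporter 1 (Homo sapiens); on this read-out lower numbers stand for stronger inhibition and higher numbers for weaker inhibition. Compound 1 `CC(C)(C)c1ccc(C(=O)N2CCC3(CC2)C(=O)N(CC(=O)N2CCC(CCO)CC2)CN3c2ccccc2)cc1` stands lower of the two: in this assay compound 1 gives 2600 nM. Compound 2 `CC(C)(C)OC(=O)NCCCNC(=O)CN1CN(c2ccccc2)C2(CCN(C(=O)c3ccc(C4CCCCC4)cc3)CC2)C1=O` is the nearest comparator; in this assay compound 2 gives 6000 nM, a higher number that lies beyond the scatter. Among the compounds with values here, compound 2 differs from compound 1 in more than one place, so no single-point step between measured compounds exists, and the two values show only that compound 1 sits lower.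

Compound 3 `CC(C)(C)c1ccc(C(=O)N2CCC3(CC2)C(=O)N(CC(=O)NCCO)CN3c2ccccc2)cc1` keeps the shared core of compound 1 and changes one place: (2-hydroxyethyl)amino in place of 4-(2-hydroxyethyl)piperidin-1-yl on a carbonyl carbon. The ring at the end of the side chain is thus cut back to an open chain that ends in the same hydroxyethyl unit.

Nothing measured tells how this assay answers such a cut. The expectation is a modest weakening, with a step from compound 1 to compound 3 estimated at a 1.5-fold higher number from compound 1 to compound 3 (0.19 log units; within the scatter) that may still fall inside the scatter. Compound 3 is accordingly expected to give 4000 nM in this assay, with a range from 1500 nM to 12000 nM.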

Compound 3, half-maximal inhibitory concentration: 1000 nM
Estimate against measurement, compound 3: 4.0-fold (0.60 log units) above, outside the stated range (below it).
By their numbers in this assay, from the lowest: compound 3; then compound 1; then compound 2.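

In this assay, within the data shown here, this position on the carbonyl carbon does not depend on the ring: (2-hydroxyethyl)amino in place of 4-(2-hydroxyethyl)piperidin-1-yl gives a 2.6-fold lower number from compound 1 to compound 3 (0.41 log units; beyond the scatter) and is the first single-place step. The side chain therefore gives up the six-membered non-aromatic ring and shrinks from 9 heavy atoms to 4 with no loss on this read-out, while the hydroxyethyl unit stays at its end. The exchange also takes the group from 1 hydrogen-bond donor to 2 and removes the ring in one move, and nothing at hand assigns the step to either difference.

The compounds shown leave open whether the terminal hydroxyl takes part at all, a question that a 2-methoxyethyl amide, an ethyl amide or a carboxylic acid at the chain end would address. Also open, going by these compounds, are the role of the amide hydrogen, which an N-methyl-N-(2-hydroxyethyl) amide would test, and the preferred chain length, which a 3-hydroxypropyl amide would probe on the same shared core.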